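The source may hold more compounds than are shown below. What is called first, only, known or untested is meant among the compounds shown, and "the series" means these compounds.

Working notes on the series, followed in an assay on membranes from brain for binding affinity to Monoglyceride lipase (Mus musculus), read by fluorescence, with stated times of 1 h and 30 min; a higher number here means a weaker inhibitor, a lower number a stronger inhibitor.

Compound 1 `O=C(NCc1ccc(OC(c2ccccc2)c2ccccc2)cc1)n1cccn1` carries the unsubstituted core. In this assay compound 1 gives only a limit, > 100000 nM. Compound 2 `N#Cc1cnn(C(=O)NCc2ccc(OC(c3ccccc3)c3ccccc3)cc2)c1` differs from compound 1 by cyano in place of hydrogen on an aromatic carbon. In this assay compound 2 likewise gives only a limit, > 100000 nM. The step that the two limits leave unreadable from compound 1 to compound 2 cannot be sized, as both ends sit at the limit of > 100000 nM in this assay, at which 2 of the 3 values shown sit.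

Compound 3 `O=C(N1CCN(C(c2ccc(OCc3ccccc3)cc2)c2ccc(OCc3ccccc3)cc2)CC1)n1cccn1` is built on a different core from compound 1; the difference between the two cores is not broken down here. In this assay, going by the values given here, compound 3 gives 3900 nM, the only number among the measured values of the set.

Compound 4 `N#Cc1cnn(C(=O)N2CCN(C(c3ccc(OCc4ccccc4)cc3)c3ccc(OCc4ccccc4)cc3)CC2)c1` is not yet measured. It differs from compound 3 by cyano in place of hydrogen on an aromatic carbon, the same change that was made from compound 1 to compound 2, at the same place on the five-membered ring. Among the compounds with values here, the one measured instance of this change is unreadable, so it gives no size to carry over; the only anchor is compound 3 with its 3900 nM. On that basis the expected step is a 2.6-fold lower number from compound 3 to compound 4 (0.41 log units; beyond the scatter), treated as modest and within or close to the usual scatter, with a wide band to cover the lack of a readable precedent. Compound 4 is estimated at 1500 nM, with the expected range running from 300 nM to 8000 nM.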

Compound 4, half-maximal inhibitory concentration: 20 nM
Beside the measured number, compound 4's estimate is 75-fold (1.88 log units) above it, and the stated range ends above it.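

In this assay, cyano in place of hydrogen on an aromatic carbon of the five-membered ring gives a 200-fold lower number from compound 3 to compound 4 (2.29 log units; beyond the scatter), so on the core of compound 3 this single change carries a large effect, well beyond the scatter. On the core of compound 1 the same change cannot be read, as both ends of that step are limits and not numbers: the limit of > 100000 nM in this assay, at which 2 of the 4 values shown sit. The series therefore holds one readable instance of the change, which shows that it can matter greatly on one core but gives no second size to set against it, and so does not show whether the effect carries from one core to the other, in size or even in direction.

The compounds shown leave open whether the step belongs to the nitrile specifically or would also appear with another group on that aromatic carbon, such as a carboxylic acid, a methyl ester or a chlorine atom. They also leave open which feature of the core of compound 3 allows a readable value at all, since the difference between the two cores is not broken down into single changes.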